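Compound 3 to compound 4 in mouse liver microsomes

A few compounds are considered here, and "the series" means these few. Any claim that something is new, unique, unknown or untested is made for them only; others in the source may bear on it.

Values measured in an in vitro ADME assay on microsomes from liver (Mus musculus) for pharmacokinetics, read by LC-MS, with a stated time of 10 min, tested at 1 uM (on this read-out higher numbers stand for fast clearance and lower numbers for slow clearance), follow
- compound 1 `Nc1ccccc1NC(=O)/C=C/c1ccc([C@H]2CN(C3COC3)C[C@@H]2C(=O)Nc2ccc(Cl)cc2)cc1` gives 42 mL/min/kg
- compound 2 `CC(C)(CO)N1C[C@H](C(=O)Nc2ccc(Cl)cc2)[C@@H](c2ccc(/C=C/C(=O)Nc3ccccc3N)cc2)C1` gives 40 mL/min/kg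
- compound 3 `CCN(CC)C(=O)N1C[C@H](C(=O)Nc2ccc(Cl)cc2)[C@@H](c2ccc(/C=C/C(=O)Nc3ccccc3N)cc2)C1` gives 83 mL/min/kg

Compound 3 stands at 83 mL/min/kg on this scale. Against its neighbours, a 2.1-fold higher number from compound 2 to compound 3 (0.32 log units; beyond the scatter) lies beyond the scatter, whereas a 2.0-fold higher number from compound 1 to compound 3 (0.30 log units; within the scatter) does not. Compound 4 `Nc1ccccc1NC(=O)/C=C/c1ccc([C@H]2CN(Cc3ccccc3)C[C@@H]2C(=O)Nc2ccc(Cl)cc2)cc1` carries benzyl in place of diethylcarbamoyl on an amine nitrogen in a ring and, like compound 1 and compound 2, has no carbonyl on that nitrogen. Among the measured compounds shown here, those two steps, read in reverse, are the only guide, and both are small. For the measured compounds named here, no measured compound carries benzyl. A downward step of similar or smaller size is therefore expected, and the estimate amounts to a 1.3-fold lower number from compound 3 to compound 4 (0.11 log units; within the scatter) in all. Compound 4 is expected at 65 mL/min/kg within an estimated range of 35 mL/min/kg to 110 mL/min/kg overall.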

Compound 4, clearance: 81 mL/min/kg
Compound 4: middle estimate off by 1.2-fold (0.10 log units), on the low side; low and high end bracket the measured number.
By their numbers in this assay, from the lowest: compounds 2, 1, 4 and 3 (each within the scatter of the next, the first and the last beyond it).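

In this assay, benzyl in place of diethylcarbamoyl gives a 1.0-fold lower number from compound 3 to compound 4 (0.01 log units; within the scatter), so a carbonyl on this nitrogen is not needed for a number as high as that of compound 3. The benzyl result also gives a 2.0-fold higher number from compound 2 to compound 4 (0.31 log units; beyond the scatter), beyond the scatter, whereas a 1.9-fold higher number from compound 1 to compound 4 (0.29 log units; within the scatter) stays within it. No available evidence explains these results. Still open, as far as these compounds go, is how an acetyl group on the same nitrogen would read, which would test a small carbonyl group. From the compounds shown here alone, a benzyl carrying a carboxylic acid is equally open.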